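The source may hold more compounds than are shown below. What is called first, only, known or untested is meant among the compounds shown, and "the series" means these compounds.

Compound 1, `C=C1C(=O)OC[C@H]1CCOC(=O)Nc1cccc(Br)c1`, gives 21800 nM in an ADME assay on RAW264.7 cells (Mus musculus) for cytotoxicity, read by MTT assay, with a stated time of 18 h; a higher number here means that more compound is tolerated, a lower number that less compound is tolerated.
Compound 2, `C=C1C(=O)OC[C@@H]1CCOC(=O)Nc1ccc(F)cc1F`, gives 14800 nM in this assay.
Compound 3, `C=C1C(=O)OC[C@@H]1CCOC(=O)Nc1ccccc1F`, gives 24200 nM in this assay.

Compound 2 stands at the lower end of these three numbers, but both compound 1 and compound 3 lie within the usual scatter of it, so the three are not separated. Compound 4, `C=C1C(=O)OC[C@H]1CCOC(=O)Nc1ccc(F)cc1F`, differs from compound 2 only in configuration as drawn: the two compounds have the same atoms and bonds and differ only in configuration as drawn: 1 of 1 stereo elements differ; a stereocentre at a saturated ring carbon is drawn R in compound 2 and S in compound 4. Among the compounds with values here, the one measured step, a 1.6-fold higher number from compound 2 to compound 3 (0.21 log units; within the scatter), concerns the removal of a fluoro group from the aromatic ring and says nothing about configuration; no measured pair differs only in the stereocentre. Compound 1 shares the drawn configuration of compound 4 but carries a different aromatic group, so its value shows only that the whole set sits in one region. On these numbers, the step from compound 2 to compound 4 is expected to stay within the scatter, a 1.1-fold higher number from compound 2 to compound 4 (0.03 log units; within the scatter). Compound 4 is therefore estimated at 16000 nM, within a range from 8000 nM to 32000 nM.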

Compound 4, half-maximal cytotoxic concentration: 24500 nM
For compound 4 the middle estimate is 1.5-fold (0.19 log units) below the measured one; low and high end bracket the measured number.
By their numbers in this assay, from the lowest: compounds 2, 1, 3 and 4 (each within the scatter of the next).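

Changing the drawn stereocentre from R to S on the shared core gives, in this assay, a 1.7-fold higher number from compound 2 to compound 4 (0.22 log units; within the scatter). Within the data shown here, the earlier step concerned only a fluoro group on the aromatic ring, so this is the first direct look at configuration, and on this one pair, R and S are not separated. Among these compounds, the comparison is a clean one, since a single stereocentre is the only thing that changes: the fact that compounds 2 and 4 differ only in the configuration as drawn.

The compounds shown leave open whether the same holds with other aromatic groups, since the bromo compound 1 and the monofluoro compound 3 each appear here in only one drawn configuration. They also leave open how this assay would respond to an amine or a carboxylic acid on the aromatic ring, or to a longer chain linking that ring to the core.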